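The source may hold more compounds than are shown below. What is called first, only, known or untested is meant among the compounds shown, and "the series" means these compounds.

Measured so far:
- compound 1 `CC(=O)N1N=C(Nc2nc3ccc(Cl)cc3s2)CC1c1ccccc1`: 161 umol/kg
- compound 2 `CC(=O)N1N=C(Nc2nc3ccccc3s2)CC1c1ccccc1`: 315 umol/kg
- compound 3 `CC(=O)N1N=C(Nc2nc3ccc([N+](=O)[O-])cc3s2)CC1c1ccccc1`: 216 umol/kg

In a functional assay on the whole organism (Hindlimb, strain albino) with Mus musculus as the target, in the maximal electroshock model, with a stated time of 0.5 h (a lower number here means that less compound is needed, a higher number that more compound is needed for the effect), compound 1 gives 161 umol/kg and cannot be separated from the other two: the data show a 2.0-fold higher number from compound 1 to compound 2 (0.29 log units; within the scatter) and a 1.3-fold higher number from compound 1 to compound 3 (0.13 log units; within the scatter). Compound 4 `CC(=O)N1N=C(Nc2nc3ccc(Cl)cc3s2)CC1OC1=CC=C1` keeps the core of compound 1 but changes the group on a saturated ring carbon: a group of 5 heavy atoms (4 carbon, 1 oxygen; one four-membered non-aromatic ring of carbon only) in place of a group of 6 heavy atoms (6 carbon; one six-membered aromatic ring of carbon only), on a saturated ring carbon. The measured steps, including a 1.5-fold lower number from compound 2 to compound 3 (0.16 log units; within the scatter), all concern an aromatic carbon, and none tests this site. Going by these compounds, they offer only a weak guide, and the direction remains open. A modest change is expected, with a 1.5-fold higher number from compound 1 to compound 4 (0.17 log units; within the scatter) as the estimated step. For compound 4, the estimated value is 240 umol/kg, with an expected range of 80 umol/kg to 700 umol/kg.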

Compound 4, dose for half-maximal effect: 212 umol/kg
Compound 4: the middle estimate sits 1.1-fold (0.05 log units) above what was measured; low and high end bracket the measured number.
By their numbers in this assay, from the lowest: compounds 1, 4, 3 and 2 (each within the scatter of the next).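

At the saturated ring carbon next to the ring nitrogen, the compounds now include a change at this site: in this assay, replacing phenyl with the group of 5 heavy atoms gives a 1.3-fold higher number from compound 1 to compound 4 (0.12 log units; within the scatter). This pair therefore shows that, at this position, phenyl can give way to a non-aromatic four-membered carbon ring carrying one hydrogen-bond acceptor without a step beyond the scatter. No available evidence accounts for this result.

Going by these compounds, whether a simple methyl, an amine or a carboxylic acid would be tolerated here remains open. So does whether this replacement behaves alike with hydrogen or nitro in place of chloro on the aromatic carbon.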